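The compounds below may be only part of what the source reports. "The series", "measured", "known", "first", "only" and "open" are said of these compounds alone.

Measured in a functional assay on HepG2 cells (Homo sapiens) for antiproliferative activity, read by MTT assay, with a stated time of 48 h; on this read-out lower numbers stand for stronger inhibition and higher numbers for weaker inhibition:

Compound 1, `N#CC1=C(N)Oc2c(N)cc3nc4ccccc4nc3c2C12C(=O)N(Cc1cnnn1-c1ccc(Cl)cc1)c1ccccc12`, gives only a limit of the assay, > 50000 nM.
Compound 2, `N#CC1=C(N)Oc2c(N)cc3nc4ccccc4nc3c2C12C(=O)N(Cc1cnnn1-c1ccccc1Cl)c1ccccc12`, gives 33500 nM.
Compound 3, `CCOc1ccccc1-n1nncc1CN1C(=O)C2(C(C#N)=C(N)Oc3c(N)cc4nc5ccccc5nc4c32)c2ccccc21`, gives 30500 nM.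

Compound 3 and compound 2 cannot be ordered against each other: the gap a 1.1-fold lower number from compound 2 to compound 3 (0.04 log units; within the scatter) lies within the scatter. The third value, that of compound 1, is a limit, (the limit of > 50000 nM in this assay, at which 1 of the 3 values shown sits). Compound 3 thus holds one of two numbers of about the same size, with the only other entry in this assay a limit.

Compound 4, `Cc1ccc(-n2nncc2CN2C(=O)C3(C(C#N)=C(N)Oc4c(N)cc5nc6ccccc6nc5c43)c3ccccc32)cc1C`, has not been measured in this assay. It differs from compound 3 by 3,4-dimethylphenyl in place of 2-ethoxyphenyl on an aromatic nitrogen. Among the measured compounds shown here, the steps that bear on this position are an at least 1.6-fold lower number from compound 1 to compound 3 (0.21 log units; that floor lies within the scatter) and an at least 1.4-fold lower number from compound 1 to compound 2 (0.17 log units; that floor lies within the scatter); both start from a limit and give only floors, each within the scatter. Among the three phenyl groups examined, the two carrying a group at the 2-position, 2-chlorophenyl and 2-ethoxyphenyl, gave numbers, while 4-chlorophenyl gave only a limit. The 3,4-dimethylphenyl of compound 4 resembles the 4-chlorophenyl case in carrying substitution at the 4-position, so a move toward weaker inhibition, possibly back to a limit, is expected, estimated as a 1.5-fold higher number from compound 3 to compound 4 (0.17 log units; within the scatter). Compound 4 is therefore expected to give about 45000 nM in this assay, within 20000 nM to 100000 nM.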

Compound 4, half-maximal inhibitory concentration: > 50000 nM
Compound 4 gave a limit, no number; the forecaster's own chance of this, stated with the estimate: 45%; at least 1.1-fold (0.04 log units) between middle value and limit.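

In this assay compound 4 gives only a limit, as compound 1 does: the limit of > 50000 nM in this assay, at which 2 of the 4 values shown sit.

Set against the groups that gave numbers, the change to 3,4-dimethylphenyl yields only floors, an at least 1.6-fold higher number from compound 3 to compound 4 (0.21 log units; that floor lies within the scatter) and an at least 1.4-fold higher number from compound 2 to compound 4 (0.17 log units; that floor lies within the scatter), so neither step is shown to exceed the scatter, and the step between the two compounds at the limit cannot be read. Across the four compounds, 2-chlorophenyl and 2-ethoxyphenyl give numbers while 4-chlorophenyl and 3,4-dimethylphenyl give limits, a split that no compound shown goes against but that rests on four compounds and on floors within the scatter.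

The compounds shown leave open whether this split follows the place of the substituent or the identity of the group, since no single group appears here in both places, as a pair of 2-ethoxyphenyl and 4-ethoxyphenyl would offer. They also leave open how the unsubstituted phenyl, or a phenyl carrying an amine or a carboxylic acid, would read on the shared core.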